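The source may report more compounds than this note shows. Statements on the series, on what has been measured and on what is new or still open speak of the compounds shown alone.

Measured so far:
- compound 1 `CCCn1c(-c2ccccc2)nc2c(NC3CCCC3)ncnc21` — 10 nM
- compound 2 `CCn1c(-c2ccccc2)nc2c(NC3CCOC3)ncnc21` — 10 nM
- compound 3 `Cn1c(-c2ccccc2)nc2c(NC3CCCC3)ncnc21` — 2.8 nM

All three numbers come from an assay on CHO cells for displacement of a labelled ligand from adenosine receptor A1 (Homo sapiens), read by scintillation counting, with a stated time of 3 h; a higher number here means a weaker inhibitor, a lower number a stronger inhibitor. Compound 3 stands at the lowest number of the three; its nearest neighbour is compound 1, and compound 2 lies at the same distance, both beyond the scatter. Among the compounds with values here, the one single-change step among the measured compounds is a 3.6-fold lower number from compound 1 to compound 3 (0.55 log units; beyond the scatter), a modest drop in the number on going to the shorter group on the chain carbon bound to the aromatic nitrogen.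

Compound 4 `CCn1c(-c2ccccc2)nc2c(NC3CCCC3)ncnc21` differs from compound 3 by methyl in place of hydrogen on a saturated chain carbon bound to an aromatic nitrogen. It thus sits between compound 3 and compound 1 on that chain, and its length matches the chain of compound 2, which carries a different amine and gives a higher number than compound 3 in this assay. Within the data shown here, the step from compound 1 to compound 3 is the only direct guide; the change to compound 4 runs the other way along the same chain, by a smaller increment. For compound 4 the estimated step is therefore a 1.8-fold higher number from compound 3 to compound 4 (0.25 log units; within the scatter). Compound 4 is estimated at 5 nM in this assay, within the range 2.5 nM to 12 nM.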

Compound 4, inhibition constant: 3.9 nM
Compound 4: the middle estimate sits 1.3-fold (0.11 log units) above what was measured; the range from low to high includes it.
By their numbers in this assay, from the lowest: compounds 3 and 4 (each within the scatter of the next); then compounds 1 and 2 (each within the scatter of the next).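

In this assay the first chain step reads a 1.4-fold higher number from compound 3 to compound 4 (0.14 log units; within the scatter); with the cyclopentyl amine held fixed, methyl in place of hydrogen on a saturated chain carbon bound to an aromatic nitrogen does not separate these two compounds. The next carbon out does separate a pair, with a 2.6-fold lower number from compound 1 to compound 4 (0.41 log units; beyond the scatter) for hydrogen in place of methyl on a saturated chain carbon, two bonds along the chain from an aromatic nitrogen, so the earlier drop from the longer chain is now seen at this outer carbon. The other position gets its first direct reading, a 2.6-fold lower number from compound 2 to compound 4 (0.41 log units; beyond the scatter), for cyclopentyl in place of oxolan-3-yl on a nitrogen on an aromatic ring. No supporting measurement bears on these steps.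

The compounds shown leave open whether a butyl chain or a branched isopropyl group on the aromatic nitrogen would follow the same course. They also leave open whether the chain steps carry over to the oxolan-3-yl amine, or to a cyclohexyl group in its place.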